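The source may hold more compounds than are shown below. What is called first, only, known or untested is meant among the compounds shown, and "the series" means these compounds.

Measured so far in an ADME assay on HEL cells (Homo sapiens) for cytotoxicity, with a stated time of 3 days; on this read-out higher numbers stand for lower toxicity in this test and lower numbers for higher toxicity in this test:
compound 1, `Cc1cn([C@@H]2O[C@H](CO)[C@@]3(OS(=O)(=O)C=C3NC(=O)NC(=O)c3ccccc3)[C@H]2O[Si](C)(C)C(C)(C)C)c(=O)n(C)c1=O`, 16000 nM
compound 2, `Cc1cn([C@@H]2O[C@H](CO)[C@@]3(OS(=O)(=O)C=C3NC(=O)NC(=O)c3ccccc3)[C@H]2O)c(=O)n(C)c1=O`, a limit of the assay, > 50000 nM
compound 3, `Cc1cn([C@@H]2O[C@H](CO[Si](C)(C)C(C)(C)C(C)C)[C@@]3(OS(=O)(=O)C=C3NC(=O)NC(=O)c3ccccc3)[C@H]2O[Si](C)(C)C(C)(C)C(C)C)c(=O)n(C)c1=O`, a limit of the assay, > 50000 nM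

Compound 2 stands at the upper limit of this assay, and only a limit is known for it. Compound 3 sits at the same limit. For the measured compounds named here, compound 1 alone gives a number, and the one step that differs in a single place, an at least 3.1-fold higher number from compound 1 to compound 2 (0.49 log units; beyond the scatter), is removal of a silyl group on an oxygen on a saturated carbon. The limit noted in the limit of > 50000 nM in this assay, at which 2 of the 3 values shown sit, caps what can be said about that step.

Compound 4, `Cc1cn([C@@H]2O[C@H](COC(=O)c3ccccc3)[C@@]3(OS(=O)(=O)C=C3NC(=O)NC(=O)c3ccccc3)[C@H]2O)c(=O)n(C)c1=O`, differs from compound 2 by benzoyl in place of hydrogen on an oxygen on a saturated carbon. Going by the values given here, no measured step adds a benzoyl group, so the only guide is that the sole measured step near this position, an at least 3.1-fold higher number from compound 1 to compound 2 (0.49 log units; beyond the scatter), moved the number toward the limit, and that two of the three values already rest there. Compound 4 is therefore expected to remain near the limit, with an at least 1.2-fold lower number from compound 2 to compound 4 (0.09 log units; that floor lies within the scatter) amounting to no change beyond the scatter, and its estimated value is 40000 nM, ranging from 15000 nM to 50000 nM.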

Compound 4, half-maximal cytotoxic concentration: > 100000 nM
Compound 4: a limit, no number; the forecaster's own chance of this, stated with the estimate: 60%; middle value at least 2.5-fold (0.39 log units) from the limit.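

Compound 2 and compound 4 both give only limits of the assay in this assay, so the step from hydroxymethyl to (benzoyloxy)methyl cannot be read. Still open, going by these compounds, is whether benzoyl in place of hydrogen on that oxygen changes the read-out at all, and in which direction.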